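From cyclopropyl to cyclohexylmethyl on an amide-type nitrogen

The source may report more compounds than this note shows. Statements on the series, on what has been measured and on what is new or still open speak of the compounds shown alone.

Among the measured compounds shown here, in an ADME assay on MRC5 cells (Homo sapiens) for inhibition, with a stated time of 72 h (on this read-out higher numbers stand for an effect only at larger amounts of compound and lower numbers for an effect already at smaller amounts), compound 1 (`CO[C@H]1CC[C@H](NC(=O)c2n[nH]cc2NC(=O)c2ncoc2-c2ccccc2)CC1`) gives 28000 nM as the only true number so far. Compound 2 (`COc1cccc(OC)c1C(=O)Nc1c[nH]nc1C(=O)NC1CC1`) stands at > 50000 nM which is a limit of the assay and not a number. Compound 3 (`COc1cccc(OC)c1C(=O)Nc1c[nH]nc1C(=O)NC1CCN(C(=O)OC(C)(C)C)CC1`) gives > 50000 nM which is likewise a limit. The main feature of the data so far is the limit of > 50000 nM in this assay, at which 2 of the 3 values shown sit, and compound 2 therefore has no exact position on the scale.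

Compound 4 (`COc1cccc(OC)c1C(=O)Nc1c[nH]nc1C(=O)NCC1CCCCC1`) is not yet measured. It carries cyclohexylmethyl in place of cyclopropyl on an amide-type nitrogen and keeps the rest of compound 2 unchanged. For the measured compounds named here, no measured pair shows a change of this kind. Going by the values given here, the expectation leans on compound 1 with 28000 nM as the one number in this assay and is therefore loose. The expected step of an at least 1.2-fold lower number from compound 2 to compound 4 (0.09 log units; that floor lies within the scatter) is small and runs towards lower numbers, with none beyond the scatter just as likely. For compound 4 the estimated value is 40000 nM with an expected range from 15000 nM to 60000 nM in this read-out.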

Compound 4, half-maximal effective concentration: > 50000 nM
Compound 4: no number, only a limit; the forecaster's own chance of this, stated with the estimate: 60%; at least 1.2-fold (0.09 log units) between middle value and limit.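

Compound 2 and compound 4 both sit at a limit of the assay and not at a number, so no step can be read between them: the limit of > 50000 nM in this assay, at which 3 of the 4 values shown sit. Still open, going by these compounds, is whether cyclohexylmethyl in place of cyclopropyl on an amide-type nitrogen changes the read-out at all.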